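Same ring atoms, joined differently

This account rests on a few compounds, and the source may have more. Where it says the series, first, only, none or still open, it means among the compounds named here.

In a physicochemical assay for lipophilicity, measured as octanol-water partition, at pH 7.4 (a lower number here means a more polar compound, a higher number a more lipophilic compound), compound 1 `Cn1cc(-c2ccc(N(C(=O)NCc3ccccc3)[C@H]3CC[C@H](Nc4ccc(C#N)cn4)CC3)cc2)cn1` gives 2.8 and compound 2 `Cn1c(-c2ccc(N(C(=O)NCc3ccccc3)[C@H]3CC[C@H](Nc4ccc(C#N)cn4)CC3)cc2)cccc1=O` gives 2.6, so compound 2 stands level with compound 1. Compound 3 `Cn1ccc(-c2ccc(N(C(=O)NCc3ccccc3)[C@H]3CC[C@H](Nc4ccc(C#N)cn4)CC3)cc2)cc1=O` has the same atoms as compound 2, joined differently: a group of 8 heavy atoms (6 carbon, 1 nitrogen, 1 oxygen; one six-membered aromatic ring with 1 hetero atom) in place of a group of 8 heavy atoms (6 carbon, 1 nitrogen, 1 oxygen; one six-membered aromatic ring with 1 hetero atom), on an aromatic carbon. Within the data shown here, the only measured exchange of one ring group for another gave a number 0.20 log units lower from compound 1 to compound 2 (within the scatter). Among the measured compounds shown here, with that small step as the sole guide, no step beyond the scatter is expected in this assay. The estimated step is a number 0.10 log units lower from compound 2 to compound 3 (within the scatter). The expected value for compound 3 is 2.5, with an estimated range of 2.1 to 2.9.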

Compound 3, distribution coefficient: 2.3
Compound 3: the middle estimate sits 0.20 log units above what was measured; the range from low to high includes it.
By their numbers in this assay, from the lowest: compounds 3, 2 and 1 (each within the scatter of the next, the first and the last beyond it).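

Rejoining the same ring atoms gives a number 0.30 log units lower from compound 2 to compound 3 (within the scatter) in this assay, so changing how this ring is attached does not, on this one pair, carry the number past the scatter. Set against the five-membered ring, however, this ring gives a number 0.50 log units lower from compound 1 to compound 3 (beyond the scatter), the first step at this position that lies beyond the scatter. Nothing available here explains either step. Still open, as far as these compounds go, is how a carboxylic acid or an amine at this place, para to a large group, would read in this assay.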